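Swapping 2-phenylethenyl for thiophen-3-yl on the shared core

The source may hold more compounds than are shown below. What is called first, only, known or untested is meant among the compounds shown, and "the series" means these compounds.

In a functional assay on HepG2 cells (Homo sapiens) for inhibition, read by MTT assay, with a stated time of 48 h (a lower number here means a stronger inhibitor, a higher number a weaker inhibitor), compound 1 `C(=C/c1nc2ccccn2c1Sc1ccccc1)\c1ccccc1` gives 8800 nM and compound 2 `Clc1ccc2nc(-c3ccccc3)c(Sc3ccccc3)n2c1` gives 15700 nM, two numbers within the scatter of each other. Compound 3 `Clc1ccc(Sc2c(-c3cccs3)nc3ccccn23)cc1` gives 59300 nM, beyond the scatter from compound 1, which therefore stands at the low end of these numbers, level with compound 2.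

Compound 4 `c1ccc(Sc2c(-c3ccsc3)nc3ccccn23)cc1` has not been measured. Its difference from compound 1 is thiophen-3-yl in place of 2-phenylethenyl on an aromatic carbon. For the measured compounds named here, no measured pair isolates this change. Compound 3 also bears a five-membered aromatic ring with 1 hetero atom at that place, and its 59300 nM suggests a higher number in this assay. The expected step is a rise beyond the scatter, a 3.4-fold higher number from compound 1 to compound 4 (0.53 log units; beyond the scatter). Compound 4 is estimated at 30000 nM, with an expected range from 11000 nM to 80000 nM.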

Compound 4, half-maximal inhibitory concentration: 49600 nM
The estimate for compound 4 lay 1.7-fold (0.22 log units) below the measured number; the measured number falls inside the stated range.
By their numbers in this assay, from the lowest: compounds 1 and 2 (each within the scatter of the next); then compounds 4 and 3 (each within the scatter of the next).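

Thiophen-3-yl in place of 2-phenylethenyl, on the aromatic carbon next to the ring nitrogen, brings a 5.6-fold higher number from compound 1 to compound 4 (0.75 log units; beyond the scatter) in this assay and gives the first comparison that differs in this one place alone. It shows that the number in this assay responds to the group at this position, and that this exchange moves it upward. No measurement at hand offers an explanation for the step.

The compounds shown leave open whether the double bond or the six-membered aromatic ring of 2-phenylethenyl matters more. They also leave open how an amine or a carboxylic acid would fare at this place.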